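Swapping a Fluorophenyl for Chloromethyl on a Shared Core

The compounds below may be only part of what the source reports. "The series", "measured", "known", "first", "only" and "open" are said of these compounds alone.

Compound 1 `Nc1nn2c(O)cc(-c3ccccc3)nc2c1[N+](=O)[O-]`: > 50 ug/mL
Compound 2 `Nc1nn2c(O)cc(-c3ccc(F)cc3)nc2c1[N+](=O)[O-]`: > 50 ug/mL

The two measured compounds share one core and differ in a single group. In a functional assay on L929 cells (Mus musculus) for inhibition (on this read-out higher numbers stand for weaker inhibition of growth and lower numbers for stronger inhibition of growth), compound 1 gives > 50 ug/mL, which is a limit of the assay and not a number. In this assay compound 2 likewise gives > 50 ug/mL, again only a limit. From the compounds shown here alone, the step that the two limits leave unreadable from compound 1 to compound 2 cannot be read because the limit of > 50 ug/mL in this assay, at which 2 of the 2 values shown sit, holds both values, so the size of the change from compound 1 to compound 2 stays unknown.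

Compound 3 `Nc1nn2c(O)cc(CCl)nc2c1[N+](=O)[O-]` has not yet been measured. The change from compound 2 to compound 3 is chloromethyl in place of 4-fluorophenyl on an aromatic carbon.

Among the compounds with values here, no measured step bears directly on this change, and the single measured step is itself unreadable. Within the data shown here, the only guide is that compound 2 sits at a limit in this assay, so nothing points to a stronger or weaker result. The estimate for compound 3 is 60 ug/mL, with a range from 15 ug/mL to 250 ug/mL. This estimate means an expected step that the limit leaves unreadable from compound 2 to compound 3, which is not expected to exceed the scatter.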

Compound 3, concentration for 50% growth inhibition: > 50 ug/mL
Compound 3 ended at the assay's limit (the forecaster's own chance of this, stated with the estimate: 65%); the middle value does not contradict the limit.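

In this assay compound 3 gives > 50 ug/mL, which is a limit and not a number. The steps to compound 3 from compound 1 and from compound 2 cannot be read, because all three compounds share one ceiling: the limit of > 50 ug/mL in this assay, at which 3 of the 3 values shown sit.

The compounds shown leave open how strongly each inhibits growth, and whether phenyl, 4-fluorophenyl or chloromethyl on the shared core makes any difference.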